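A longer methylpiperazine chain: compound 3 to compound 4

The compounds below may be only part of what the source reports. "The series", "measured", "known", "first", "only" and "open" are said of these compounds alone.

- Compound 1 `COc1c(OCc2cnoc2C)cc(O)c2c(=O)cc(-c3ccccc3)oc12`: > 100000 nM (a limit)
- Compound 2 `COc1c(OCc2ncc(C)o2)cc(O)c2c(=O)cc(-c3ccccc3)oc12`: > 100000 nM (a limit)
- Compound 3 `COc1c(OCCCN2CCN(C)CC2)cc(O)c2c(=O)cc(-c3ccccc3)oc12`: 9900 nM

Going by the values given here, in a functional assay on A549 cells (Homo sapiens) for cytotoxicity, read by MTT assay, with a stated time of 48 h (on this read-out higher numbers stand for weaker inhibition and lower numbers for stronger inhibition), compound 3 gives 9900 nM, the only true number here. The entries for compound 1 and compound 2 are limits of the assay. Compound 4 `COc1c(OCCCCN2CCN(C)CC2)cc(O)c2c(=O)cc(-c3ccccc3)oc12` differs from it as follows: (4-methylpiperazin-1-yl)methyl in place of 4-methylpiperazin-1-yl on a saturated chain carbon, three bonds along the chain from an oxygen on an aromatic ring. This turns 2-(4-methylpiperazin-1-yl)ethyl into 3-(4-methylpiperazin-1-yl)propyl. The two steps that bear on this are an at least 10-fold lower number from compound 1 to compound 3 (1.00 log units; beyond the scatter) and an at least 10-fold lower number from compound 2 to compound 3 (1.00 log units; beyond the scatter), both of which brought in the methylpiperazine chain. Among the compounds with values here, no measured step changes the chain length alone, and compound 4 keeps the 4-methylpiperazin-1-yl group, so only a small change is expected. The expected step is a 1.2-fold lower number from compound 3 to compound 4 (0.09 log units; within the scatter). Compound 4 is estimated at 8000 nM, with an expected range of 3000 nM to 25000 nM.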

Compound 4, half-maximal inhibitory concentration: 1500 nM
Compound 4: middle estimate off by 5.3-fold (0.73 log units), on the high side, outside the stated range (below it).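

Lengthening the chain at this position matters: 3-(4-methylpiperazin-1-yl)propyl in place of 2-(4-methylpiperazin-1-yl)ethyl gives a 6.6-fold lower number from compound 3 to compound 4 (0.82 log units; beyond the scatter), the only step shown that changes chain length alone. The longer chain also widens the gap to the two methyl-substituted five-membered rings, with an at least 66-fold lower number from compound 2 to compound 4 (1.82 log units; beyond the scatter) and an at least 66-fold lower number from compound 1 to compound 4 (1.82 log units; beyond the scatter). The entries for compound 1 and compound 2 are limits, not numbers, so these two sizes are minimums: the limit of > 100000 nM in this assay, at which 2 of the 4 values shown sit.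

As far as these compounds go, whether a still longer chain, such as 4-(4-methylpiperazin-1-yl)butyl, lowers the number further remains open. So does whether a morpholine or a dimethylamine at the chain end would serve as well as the methylpiperazine.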